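Replacing 4-bromophenyl with 3-methoxyphenyl in compound 1

The compounds below may be only part of what the source reports. "The series", "measured", "known", "first", "only" and "open" are said of these compounds alone.

Compound 1 `COc1cc(OC)c(OC)cc1/C=C/COC(=O)/C=C/c1ccc(Br)cc1` gives 143 umol/kg
Compound 2 `COc1cc(OC)c(OC)cc1/C=C/COC(=O)/C=C/c1cc(OC)c(OC)c(OC)c1` gives 74.7 umol/kg
Compound 3 `COc1cc(OC)c(OC)cc1/C=C/COC(=O)/C=C/c1ccc(OC)c(OC)c1OC` gives 75.1 umol/kg

All three compounds were measured in a functional assay on the whole organism (strain Kunming) with Mus musculus as the target, with a stated time of 0.5 h (on this read-out lower numbers stand for an effect already at smaller amounts and higher numbers for an effect only at larger amounts of compound), and lie within the usual scatter of one another, so compound 1 stands level with compound 2 and compound 3 on these numbers. Compound 4 `COc1cccc(/C=C/C(=O)OC/C=C/c2cc(OC)c(OC)cc2OC)c1` keeps the core of compound 1 but carries 3-methoxyphenyl in place of 4-bromophenyl on a double-bonded chain carbon bound to a double-bonded chain carbon. Among the measured compounds shown here, no measured pair isolates this exchange. Compound 2 with 74.7 umol/kg and compound 3 with 75.1 umol/kg stay within the scatter of compound 1, so no change beyond the scatter is expected in this assay for this exchange. The expected step of a 1.4-fold lower number from compound 1 to compound 4 (0.16 log units; within the scatter) is small and within the scatter. For compound 4 the estimated value is 100 umol/kg with an expected range from 50 umol/kg to 200 umol/kg in this read-out.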

Compound 4, dose for half-maximal effect: 190 umol/kg
Compound 4: the middle estimate sits 1.9-fold (0.28 log units) below what was measured; the range from low to high includes it.
By their numbers in this assay, from the lowest: compounds 2, 3, 1 and 4 (each within the scatter of the next, the first and the last beyond it).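

In this assay, among the compounds shown here, 3-methoxyphenyl in place of 4-bromophenyl on a double-bonded chain carbon bound to a double-bonded chain carbon gives a 1.3-fold higher number from compound 1 to compound 4 (0.12 log units; within the scatter), the first direct reading of this exchange. On these numbers the two groups cannot be told apart at this position, although the entering group brings a hydrogen-bond acceptor that the leaving group lacks. No evidence is available that bears on this result.

Going by these compounds, whether an amine or a carboxylic acid in place of 4-bromophenyl would move the number beyond the scatter remains open.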